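Chloro for Fluoro on the Aryl Ring of Compound 2

The source may report more compounds than this note shows. Statements on the series, on what has been measured and on what is new or still open speak of the compounds shown alone.

Compound 2 `O=C(Nc1nc2ccccc2s1)c1cn(-c2ccccc2)nc1-c1ccc(F)cc1` was tested in a functional assay on HT-29 cells (Homo sapiens) for cytotoxicity, read by MTT assay, with a stated time of 72 h (on this read-out higher numbers stand for weaker inhibition and lower numbers for stronger inhibition), where compound 2 gives 9060 nM. Its number is not separated from compound 1 `O=C(Nc1nc2ccccc2s1)c1cn(-c2ccccc2)nc1-c1ccccc1`, which in this assay gives 16800 nM, by more than the scatter, whereas compound 3 `Cc1ccc2nc(NC(=O)c3cn(-c4ccccc4)nc3-c3ccc(F)cc3)sc2c1`, giving 22900 nM in this assay, stands apart from it. The two measured steps are a 1.9-fold lower number from compound 1 to compound 2 (0.27 log units; within the scatter) and a 2.5-fold higher number from compound 2 to compound 3 (0.40 log units; beyond the scatter). Compound 4 `O=C(Nc1nc2ccccc2s1)c1cn(-c2ccccc2)nc1-c1ccc(Cl)cc1` differs from compound 2 by chloro in place of fluoro on an aromatic carbon. Of the measured steps, a 1.9-fold lower number from compound 1 to compound 2 (0.27 log units; within the scatter) concerns the same place on the same ring and is the one that bears here; it stayed within the scatter. Within the data shown here, no measured compound carries chloro, so nothing shows whether the second halogen at this place moves the number. The expected step is a 1.2-fold lower number from compound 2 to compound 4 (0.08 log units; within the scatter), that is, no change beyond the scatter. Compound 4 is estimated at 7500 nM, with a range from 3000 nM to 20000 nM.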

Compound 4, half-maximal inhibitory concentration: 13700 nM
Compound 4: middle estimate off by 1.8-fold (0.26 log units), on the low side; the range from low to high includes it.
By their numbers in this assay, from the lowest: compounds 2, 4, 1 and 3 (each within the scatter of the next, the first and the last beyond it).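

In this assay the change from one halogen to the other at this place gives a 1.5-fold higher number from compound 2 to compound 4 (0.18 log units; within the scatter) and the chloro compound set against the unsubstituted phenyl gives a 1.2-fold lower number from compound 1 to compound 4 (0.09 log units; within the scatter) so neither step leaves the scatter. Together with the earlier fluoro step, this means that hydrogen, fluoro and chloro, on an aromatic carbon para to a large group, cannot be told apart on this read-out across compound 1, compound 2 and compound 4. Nothing available explains why this place tolerates all three. The compounds shown leave open whether a group of another kind here, such as an amine, a carboxylic acid or a methoxy group, would move the number beyond the scatter. Also open, from the compounds shown here alone, is whether chloro at this place would read the same alongside the added methyl of compound 3.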